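The compounds below may be only part of what the source reports. "The series", "measured", "known", "first", "only" and "open" are said of these compounds alone.

Compound 2, `Cn1c(-c2ccc(Cl)cc2)c(CCC(=O)N2CCN(Cc3ccccc3)CC2)c2cc(Cl)ccc21`, binds the Substance-P receptor strongly: in an assay on CHO cells with Substance-P receptor (Homo sapiens) as the target (a lower number here means a stronger inhibitor, a higher number a weaker inhibitor), compound 2 gives 0.3 nM. That is the lower of the two numbers measured here. For the measured compounds named here, the only other measured compound, compound 1, `COc1ccccc1N1CCN(C(=O)CCc2c(-c3ccc(Br)cc3)[nH]c3ccc(C)cc23)CC1`, differs from it in several places at once, so no single step links the two; in this assay compound 1 gives 1 nM, and the gap between compound 2 and compound 1 lies beyond the usual scatter of this kind of measurement.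

Compound 3, `CC(C)N1CCN(C(=O)CCc2c(-c3ccc(Cl)cc3)n(C)c3ccc(Cl)cc23)CC1`, has not yet been measured. It keeps the core of compound 2 and changes one group: isopropyl in place of benzyl on an amine nitrogen in a ring. Going by the values given here, no measured pair shows what happens when a benzyl on this amine nitrogen in a ring is exchanged for a smaller group, so the size of this step is not known from the numbers at hand. A benzyl is the larger of the two groups, and its removal is expected to cost some binding, so a step upward in this assay of modest size is expected from compound 2 to compound 3, a 10-fold higher number from compound 2 to compound 3 (1.00 log units; beyond the scatter). Compound 3 is therefore expected to give 3 nM in this assay, within a range from 0.8 nM to 15 nM.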

Compound 3, half-maximal inhibitory concentration: 13 nM
Compound 3: the middle estimate sits 4.3-fold (0.64 log units) below what was measured; the measured number falls inside the stated range.
By their numbers in this assay, from the lowest: compound 2; then compound 1; then compound 3.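

Exchanging benzyl for isopropyl on this amine nitrogen in a ring, with the rest of the molecule unchanged, produces a 43-fold higher number from compound 2 to compound 3 (1.64 log units; beyond the scatter) in this assay and so shows that binding depends strongly on the group at this position. For the compounds shown here, compound 1 differs from compound 2 in several places at once, so the earlier numbers could not isolate this position; this is the first comparison in which only one group changes, and the step is large and beyond the usual scatter. Nothing at hand explains why the loss of binding is this large.

The exchange removes a six-membered aromatic ring of carbon and also shrinks the group from 7 heavy atoms to 3, so the compounds shown cannot separate the part played by the ring from the part played by the size of the group. Going by these compounds, a cyclohexylmethyl group, which keeps a ring without the aromatic one, or a phenethyl group, which has a longer chain leading to the same aromatic ring, would help to separate the two, and how either would fare at this position remains open.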